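A few compounds are considered here, and "the series" means these few. Any claim that something is new, unique, unknown or untested is made for them only; others in the source may bear on it.

Values measured so far in a functional assay on L1210 cells (Mus musculus) for inhibition; on this read-out lower numbers stand for stronger inhibition and higher numbers for weaker inhibition
Compound 1 `O=C1CCCCC/C1=C\c1ccccc1` at 261000 nM
Compound 2 `O=C1CCCCC/C1=C\c1cccc(Br)c1` at 246000 nM

Within the data shown here, compound 2 stands level with compound 1, the only other compound measured, and the value for compound 2 of 246000 nM cannot be told apart from that of its neighbour. The measured step is a 1.1-fold lower number from compound 1 to compound 2 (0.03 log units; within the scatter) and it lies within the scatter. The next compound to be read in this assay is compound 3 `COc1cccc(/C=C2\CCCCCC2=O)c1` and it differs from compound 2 by methoxy in place of bromo on an aromatic carbon on the same shared core. In words, this is methoxy in place of bromo on an aromatic carbon.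

Among the measured compounds shown here, only one measured step bears on this change. Placing bromo on the ring gave a 1.1-fold lower number from compound 1 to compound 2 (0.03 log units; within the scatter) and so left the number within the scatter. For the measured compounds named here, no compound with a methoxy group has yet been measured, so this single step is thin evidence, and it gives no direction for the change. The expected step is a 1.0-fold lower number from compound 2 to compound 3 (0.01 log units; within the scatter) and it is estimated to stay within the scatter. For compound 3 the estimated value is 240000 nM with an expected range from 120000 nM to 450000 nM in this read-out.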

Compound 3, half-maximal inhibitory concentration: 283000 nM
Beside the measured number, compound 3's estimate is 1.2-fold (0.07 log units) below it; the measured number falls inside the stated range.
By their numbers in this assay, from the lowest: compounds 2, 1 and 3 (each within the scatter of the next).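

In this assay, this aromatic carbon has now carried a third substituent, and methoxy in place of bromo gives a 1.2-fold higher number from compound 2 to compound 3 (0.06 log units; within the scatter) while methoxy in place of hydrogen gives a 1.1-fold higher number from compound 1 to compound 3 (0.04 log units; within the scatter) on the same shared core. The result extends the earlier bromo comparison: hydrogen, bromo and methoxy cannot be told apart here, even though methoxy brings two heavy atoms and a hydrogen-bond acceptor where bromo brings one heavy atom and no acceptor. No measurement is available that would explain this lack of separation.

The three compounds leave open whether any group at this aromatic carbon can move the number beyond the scatter, as an amine or a carboxylic acid might be tested to show. They also leave open whether a change elsewhere on the shared core, such as a longer chain in place of a ring hydrogen or an altered carbonyl, would separate compounds in a way that these three substituents do not.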